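Amino Substitution on Two Benzyl Isomers: Expected Cytotoxicity

A few compounds are considered here, and "the series" means these few. Any claim that something is new, unique, unknown or untested is made for them only; others in the source may bear on it.

The series was examined in a functional assay on NCI/ADR-RES cells (Homo sapiens) for cytotoxicity, read by sulforhodamine B assay, with a stated time of 48 h; on this read-out higher numbers stand for weaker inhibition of growth and lower numbers for stronger inhibition of growth. Compound 1 `ClCc1ccc(Cn2cnc3c(Cl)ncnc32)cc1` gives 1510 nM in this assay. Compound 2 `Nc1nc(Cl)c2ncn(Cc3ccc(CCl)cc3)c2n1` differs from it by one change, (amino in place of hydrogen on an aromatic carbon), and in this assay compound 2 gives 3310 nM. This change made the step of a 2.2-fold higher number from compound 1 to compound 2 (0.34 log units; beyond the scatter).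

Compound 3 `ClCc1ccccc1Cn1cnc2c(Cl)ncnc21` has the same atoms as compound 1 joined differently; the difference between the two cores is not broken down here. In this assay compound 3 gives 2180 nM, which lies within the usual scatter of both compound 1 and compound 2, so no order among the three can be claimed from these numbers alone.

Compound 4 `Nc1nc(Cl)c2ncn(Cc3ccccc3CCl)c2n1` has not yet been measured. It differs from compound 3 by amino in place of hydrogen on an aromatic carbon, the same kind of change that carried compound 1 to compound 2, occurring twice among the compounds shown; the place description is the same word for word in both cases. Because the earlier instance gave a 2.2-fold higher number from compound 1 to compound 2 (0.34 log units; beyond the scatter), a step of similar size is expected in this assay from compound 3, namely a 2.1-fold higher number from compound 3 to compound 4 (0.31 log units; beyond the scatter). On that basis compound 4 is estimated to give 4500 nM in this assay, with a range from 2200 nM to 9500 nM expected to hold most repeated measurements. The estimate rests on a single matched pair, so its uncertainty is wide.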

Compound 4, concentration for 50% growth inhibition: 4470 nM
Estimate against measurement, compound 4: 1.0-fold (0.00 log units) above; measured number inside the range.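

Amino in place of hydrogen on an aromatic carbon gave a 2.1-fold higher number from compound 3 to compound 4 (0.31 log units; beyond the scatter) in this assay, and this step matches the one seen on the other core: the same change on two cores in this assay, a 2.2-fold higher number (0.34 log units; beyond the scatter) from compound 1 to compound 2 and a 2.1-fold higher number (0.31 log units; beyond the scatter) from compound 3 to compound 4, 1.1-fold (0.03 log units) apart, within the scatter of two such steps. Across these two pairs, the change therefore carried from one core to the other with its direction and size preserved, and in both cases the number rose, which on this read-out stands for weaker inhibition of growth. Among these compounds, the result rests on only two matched pairs, both modest steps in a single cell line, so it does not show that the change would carry to any further core or to another read-out, and it gives no reason for the shift.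

The compounds shown leave open whether another group at the same place, such as a methylamino group, a hydroxyl or a methoxy group, would move the number as amino does, or whether amino is particular in this respect. They also leave open whether the step would keep its size if the chloro group on the same ring gave way to an amine or a thioether, since both cores shown carry that chloro group throughout.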